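A few compounds are considered here, and "the series" means these few. Any claim that something is new, unique, unknown or untested is made for them only; others in the source may bear on it.

Compound 1 `NC(=S)Nc1cccc(OCCCc2ccccc2)c1`: > 50000 nM
Compound 2 `NC(=S)Nc1cccc(OCCCCCCCc2ccccc2)c1`: 23000 nM
Compound 3 `NC(=S)Nc1cccc(OCCCCCOc2ccc(Cl)cc2)c1`: 7000 nM

In an ADME assay on Ava5 cells (Homo sapiens) for cytotoxicity (on this read-out lower numbers stand for higher toxicity in this test and higher numbers for lower toxicity in this test), compound 1 gives only a limit of the assay, > 50000 nM. Compound 2 gives 23000 nM and compound 3 gives 7000 nM, which is the lowest of the two numbers shown. The remaining value, that of compound 1, is a limit. For the measured compounds named here, the one measured step is a 3.3-fold lower number from compound 2 to compound 3 (0.52 log units; beyond the scatter). Compound 4 `NC(=S)Nc1cccc(OCCCCCOc2ccc(-c3cccs3)cc2)c1` has not yet been measured; it differs from compound 3 in one place: thiophen-2-yl in place of chloro on an aromatic carbon. Going by the values given here, no measured step exchanges a group on the aromatic ring of the 4-chlorophenoxy part, so none bears directly on this change; the nearest comparison is the step of a 3.3-fold lower number from compound 2 to compound 3 (0.52 log units; beyond the scatter), which replaced one end group with another and gave a modest lowering. On that basis a modest lowering, or no step beyond the scatter, is expected for compound 4, a 2.0-fold lower number from compound 3 to compound 4 (0.30 log units; within the scatter). Compound 4 is estimated to give 3500 nM in this assay, with a range from 1200 nM to 12000 nM.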

Compound 4, half-maximal cytotoxic concentration: > 50000 nM
Compound 4: no number, only a limit; the forecaster's own chance of this, stated with the estimate: 5%; middle value at least 14-fold (1.15 log units) away from the limit.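

In this assay, the group on this aromatic carbon, para to a large group, clearly affects the read-out: thiophen-2-yl in place of chloro gives an at least 7.1-fold higher number from compound 3 to compound 4 (0.85 log units; beyond the scatter), a move in the opposite direction to the earlier end-group change, a 3.3-fold lower number from compound 2 to compound 3 (0.52 log units; beyond the scatter). As far as these compounds go, compound 4 gives > 50000 nM, which is a limit, so the full size of the step stays unknown. The read-out offers no further room on this side: the limit of > 50000 nM in this assay, at which 2 of the 4 values shown sit.

The compounds shown do not tell whether the new ring, its sulfur or simply the larger group accounts for the step. From the compounds shown here alone, it also remains open whether phenyl or a smaller group such as fluoro or methoxy at this position would give a number close to that of compound 3 or reach the same limit as compound 4.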